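One more methoxy on compound 3

The source may hold more compounds than are shown below. What is called first, only, known or untested is meant among the compounds shown, and "the series" means these compounds.

In a functional assay on SGC-7901 cells (Homo sapiens) for antiproliferative activity, read by MTT assay, with a stated time of 48 h (a higher number here means a weaker inhibitor, a lower number a stronger inhibitor), three compounds have been measured so far. Compound 1 (`COc1ccc(-c2nnc(SCc3ccc(Cl)nc3)o2)cc1`) gives 3.5 ug/mL, compound 2 (`Fc1ccccc1-c1nnc(SCc2ccc(Cl)nc2)o1`) gives 9.12 ug/mL, and compound 3 (`COc1ccc(-c2nnc(SCc3ccc(Cl)nc3)o2)cc1OC`) gives 4.48 ug/mL. Compound 3 therefore sits within the scatter of compound 1, while compound 2 carries a higher number, and its gap to compound 3 lies beyond the scatter.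

Compound 4 (`COc1ccc(-c2nnc(SCc3ccc(Cl)nc3)o2)c(OC)c1OC`) is not yet measured. It departs from compound 3 by a single change: methoxy in place of hydrogen on an aromatic carbon. Within the data shown here, only one measured step is of the same kind, methoxy in place of hydrogen on an aromatic carbon, and that is a 1.3-fold higher number from compound 1 to compound 3 (0.11 log units; within the scatter). This step stays within the scatter. Among the measured compounds shown here, compound 2 offers no direct comparison, since no single-place step links it to compound 3. For the measured compounds named here, one step is thin evidence, and no measurement yet covers a methoxy group at the place it takes in compound 4, so the range is kept wide.

On this evidence, no step beyond the scatter is expected in this assay. The expected change is a 1.1-fold higher number from compound 3 to compound 4 (0.05 log units; within the scatter). For compound 4 the estimated value is 5 ug/mL, with an expected range from 2.5 ug/mL to 10 ug/mL.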

Compound 4, half-maximal inhibitory concentration: 10.2 ug/mL
Beside the measured number, compound 4's estimate is 2.0-fold (0.31 log units) below it; measured number outside the range, above it.
By their numbers in this assay, from the lowest: compounds 1 and 3 (each within the scatter of the next); then compounds 2 and 4 (each within the scatter of the next).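

In this assay, the same replacement, methoxy in place of hydrogen on an aromatic carbon, gives a 1.3-fold higher number from compound 1 to compound 3 (0.11 log units; within the scatter) at its earlier place but a 2.3-fold higher number from compound 3 to compound 4 (0.36 log units; beyond the scatter) at the new one, so this change does not behave alike at every place on the ring. The step from compound 3 to compound 4 is modest but beyond the scatter, and it marks the new place, ortho to a large group, ortho to a methoxy group and meta to a methoxy group, as the first on this ring where adding a methoxy group gives a readable loss in this series. No measurement shown accounts for this step.

The compounds shown do not separate the place itself from the methoxy groups already on the ring, since a lone methoxy group at this place, without the other two, does not appear among them. On these data alone, whether a smaller or different group there, such as a hydroxy group, an amine or a chlorine atom, would give a step of similar size also remains open.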